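The compounds below may be only part of what the source reports. "The series", "measured", "known", "first", "only" and "open" are said of these compounds alone.

Three esters built on one shared core have been tested in a functional assay on A549 cells (Homo sapiens) for cytotoxicity, read by MTT assay, with a stated time of 48 h; on this read-out higher numbers stand for weaker inhibition and lower numbers for stronger inhibition. Compound 1 `C=C1C(=O)O[C@H]2CC3=C[C@H](C/C(C)=C/[C@@H](OC(=O)c4ccc(-c5ccccc5)cc4)[C@H]12)OC3=O` gives 4600 nM. Compound 3 `C=C1C(=O)O[C@H]2CC3=C[C@H](C/C(C)=C/[C@@H](OC(=O)C4(NC(=O)OCc5ccccc5)CC4)[C@H]12)OC3=O` gives 5800 nM. These two numbers lie within the usual scatter of each other, so no order between them can be read. Compound 2 `C=C1C(=O)O[C@H]2CC3=C[C@H](C/C(C)=C/[C@@H](OC(=O)CCCCC)[C@H]12)OC3=O` reaches only a limit of the assay, > 10000 nM, so no number is known for it. That reading stands at the limit of > 10000 nM in this assay, at which 1 of the 3 values shown sits. Compound 4 `C=C1C(=O)O[C@H]2CC3=C[C@H](C/C(C)=C/[C@@H](OC(=O)/C=C/c4ccncc4)[C@H]12)OC3=O` has not yet been measured. It differs from compound 2 in one place: 2-(pyridin-4-yl)ethenyl in place of pentyl on a carbonyl carbon. The two esters that gave numbers, compound 1 at 4600 nM and compound 3 at 5800 nM, both gave measurable values, and compound 4 is expected to join them rather than compound 2. The step of an at least 2.0-fold lower number from compound 2 to compound 4 (0.30 log units; that floor lies within the scatter) is therefore expected to run toward stronger inhibition and beyond the scatter, though its exact size cannot be fixed from a limit. For compound 4 the estimate is 5000 nM, with a range from 2500 nM to 10000 nM.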

Compound 4, half-maximal inhibitory concentration: 4000 nM
The estimate for compound 4 lay 1.3-fold (0.10 log units) above the measured number, and the stated range covers the measured number.
By their numbers in this assay, from the lowest: compounds 4, 1 and 3 (each within the scatter of the next). At a limit, above all of these: compound 2.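

In this assay, going by these compounds alone, putting 2-(pyridin-4-yl)ethenyl in place of pentyl on a carbonyl carbon gives an at least 2.5-fold lower number from compound 2 to compound 4 (0.39 log units; beyond the scatter), the first step at this position that can be read, and its true size may be larger. Compound 2 stands at a limit of the assay rather than at a number: the limit of > 10000 nM in this assay, at which 1 of the 4 values shown sits. Among the four esters, the one whose group has no ring is also the only one at that limit, so this position does respond to the group it carries.

The change brings in a ring, a ring nitrogen and a double bond all at once, so the step cannot be assigned to any one of them. A 2-phenylethenyl or a 2-(pyridin-4-yl)ethyl group at this position would separate these parts.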